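Fluoro-carboxyphenyl ether analogue of a chloro-substituted modulator

The source may hold more compounds than are shown below. What is called first, only, known or untested is meant among the compounds shown, and "the series" means these compounds.

Measured compounds:
compound 1, `Cc1c(OCCCCOc2ccc(C(=O)O)cc2)ccc(C(=O)CC(C)C)c1O`: 122 nM
compound 2, `CCCC(=O)c1ccc(OCCCCOc2ccc(F)c(C(=O)O)c2)c(C)c1O`: 74 nM
compound 3, `Cc1c(OCCCCOc2ccc(C(=O)O)cc2Cl)ccc(C(=O)CC(C)C)c1O`: 96 nM

In an assay on HEK293 cells for positive allosteric modulation of metabotropic glutamate receptor 2 (Rattus norvegicus), read by thallium flux, with a stated time of 2.5 min (a lower number here means that less compound is needed, a higher number that more compound is needed for the effect), compound 3 gives 96 nM, the second highest of the three numbers. Compound 1 lies nearest, and the step of a 1.3-fold lower number from compound 1 to compound 3 (0.10 log units; within the scatter) is within the scatter; compound 2 is furthest, and its number is also within the scatter of that of compound 3, so no order can be read among them.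

Compound 4, `Cc1c(OCCCCOc2ccc(F)c(C(=O)O)c2)ccc(C(=O)CC(C)C)c1O`, has not been measured. It differs from compound 3 in one place: 3-carboxy-4-fluorophenyl in place of 4-carboxy-2-chlorophenyl on an oxygen on a saturated carbon. Among the compounds with values here, only one measured step bears on this change, the step of a 1.3-fold lower number from compound 1 to compound 3 (0.10 log units; within the scatter), which touches the leaving chloro group and is within the scatter. Compound 2 carries the same entering 3-carboxy-4-fluorophenyl group as compound 4 but differs from compound 3 in a second place as well, so only what compound 2 shows, 74 nM, can be noted. The expectation is therefore a step of a 1.2-fold lower number from compound 3 to compound 4 (0.08 log units; within the scatter) that stays within the scatter, and compound 4 is estimated at 80 nM, with a range from 40 nM to 160 nM.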

Compound 4, half-maximal effective concentration: 153 nM
Compound 4: the middle estimate sits 1.9-fold (0.28 log units) below what was measured; the range from low to high includes it.
By their numbers in this assay, from the lowest: compounds 2, 3, 1 and 4 (each within the scatter of the next, the first and the last beyond it).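

In this assay, 3-carboxy-4-fluorophenyl in place of 4-carboxy-2-chlorophenyl on the oxygen gives a 1.6-fold higher number from compound 3 to compound 4 (0.20 log units; within the scatter) and so leaves no readable change, and the same holds against the 4-carboxyphenyl group, with a 1.3-fold higher number from compound 1 to compound 4 (0.10 log units; within the scatter) as the step. The three groups on this oxygen are therefore not told apart here, although the carboxylic acid stands at a different place on the ring in compound 4. Within the data shown here, with 3-carboxy-4-fluorophenyl held fixed, the only step beyond the scatter, and a modest one, lies in the chain rather than at this position: a 2.1-fold higher number from compound 2 to compound 4 (0.32 log units; beyond the scatter) for methyl in place of hydrogen on a saturated chain carbon.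

No evidence at hand accounts for these numbers. Going by these compounds, it remains open whether a tetrazole or an amide in place of the carboxylic acid, or a longer chain between the two oxygens, would move the number beyond the scatter.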